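Swapping the acyl aryl group on a thiazole urea hydrazone

A few compounds are considered here, and "the series" means these few. Any claim that something is new, unique, unknown or untested is made for them only; others in the source may bear on it.

Two close analogues have been tested in a functional assay on BCG823 cells (Homo sapiens) for inhibition, read by MTT assay, with a stated time of 72 h; a higher number here means a weaker inhibitor, a lower number a stronger inhibitor. Compound 1 `CN(C(=O)NC(=O)c1ccc(Cl)cc1Cl)c1nc(C(F)(F)F)c(C(=O)N/N=C/c2ccc(C(F)(F)F)cc2)s1` gives 3.08 ug/mL. Compound 2 `CN(C(=O)NC(=O)c1ccccc1F)c1nc(C(F)(F)F)c(C(=O)N/N=C/c2cccc(C(F)(F)F)c2)s1` gives 16.3 ug/mL, the higher of the two numbers and beyond the scatter away from compound 1. The next compound, compound 3 `CN(C(=O)NC(=O)c1ccc(Cl)cc1Cl)c1nc(C(F)(F)F)c(C(=O)N/N=C/c2cccc(C(F)(F)F)c2)s1`, differs from compound 2 in a single place: 2,4-dichlorophenyl in place of 2-fluorophenyl on a carbonyl carbon. Compound 3 thus carries the same acyl group as compound 1 while keeping the rest of its structure in common with compound 2. Because compound 1 gives 3.08 ug/mL with this acyl group, the step of a 2.7-fold lower number from compound 2 to compound 3 (0.43 log units; beyond the scatter) is expected to be a moderate move toward a lower number, though the remaining difference from compound 1 leaves the size uncertain. In this assay compound 3 is therefore estimated at 6 ug/mL, with a plausible range from 2.5 ug/mL to 15 ug/mL.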

Compound 3, half-maximal inhibitory concentration: 6.11 ug/mL
Compound 3: middle estimate off by 1.0-fold (0.01 log units), on the low side; measured number inside the range.
By their numbers in this assay, from the lowest: compounds 1 and 3 (each within the scatter of the next); then compound 2.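

In this assay the acyl aryl group on the carbonyl carbon can now be read on its own: 2,4-dichlorophenyl in place of 2-fluorophenyl gives a 2.7-fold lower number from compound 2 to compound 3 (0.43 log units; beyond the scatter), a modest step that the first two compounds, which differ in two places, could not isolate. The group on the carbon with a double bond to nitrogen can also be read: 3-(trifluoromethyl)phenyl in place of 4-(trifluoromethyl)phenyl gives a 2.0-fold higher number from compound 1 to compound 3 (0.30 log units; within the scatter), so these two groups are not told apart here. Nothing measured here accounts for either step.

As far as these compounds go, how the acyl position would respond to 4-chlorophenyl, 2-chlorophenyl or unsubstituted phenyl remains open, so the part played by each chlorine cannot be separated. From the compounds shown here alone, whether a pyridine ring or a longer chain would be tolerated at that carbonyl carbon also remains open.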